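Pyridin-3-yl in Place of Furanylmethyl on a Weak Amide

A few compounds are considered here, and "the series" means these few. Any claim that something is new, unique, unknown or untested is made for them only; others in the source may bear on it.

Compound 2 `O=C(NCc1ccco1)c1ccccc1OCc1ccccc1` gives 49000 nM in an assay on lysate for inhibition of phosphatidylcholine:ceramide cholinephosphotransferase 2 (Homo sapiens), read by HPLC, with stated times of 30 min and 2 h (a lower number here means a stronger inhibitor, a higher number a weaker inhibitor), the higher of the two numbers measured, though only within the scatter; compound 1 `O=C(NCc1ccccc1)c1ccccc1OCc1ccccc1` gives 34200 nM, and the step of a 1.4-fold higher number from compound 1 to compound 2 (0.16 log units; within the scatter) was small. Compound 3 `O=C(Nc1cccnc1)c1ccccc1OCc1ccccc1` differs from compound 2 by pyridin-3-yl in place of (furan-2-yl)methyl on an amide-type nitrogen. For the measured compounds named here, only that one earlier step, at the same amide-type nitrogen, bears on this change, and it lay within the scatter, so a step of similar size and no clear direction is expected here, giving an estimated 1.2-fold lower number from compound 2 to compound 3 (0.09 log units; within the scatter). Compound 3 is therefore expected to give 40000 nM, with a range of 15000 nM to 110000 nM.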

Compound 3, half-maximal inhibitory concentration: 3200 nM
The estimate for compound 3 lay 13-fold (1.10 log units) above the measured number, outside the stated range (below it).
By their numbers in this assay, from the lowest: compound 3; then compounds 1 and 2 (each within the scatter of the next).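

At the amide-type nitrogen, the earlier swap of ring stayed within the scatter, but in this assay pyridin-3-yl gives a 15-fold lower number from compound 2 to compound 3 (1.19 log units; beyond the scatter) against (furan-2-yl)methyl and an 11-fold lower number from compound 1 to compound 3 (1.03 log units; beyond the scatter) against benzyl. This shows that the group on this nitrogen can shift the number strongly, and both large steps involve the ring sitting directly on the nitrogen, with no chain carbon. No measurement shown here explains the size of these steps. Still open, going by these compounds, is whether the ring nitrogen or the missing chain carbon matters more; phenyl or pyridin-3-ylmethyl on the same amide nitrogen would separate the two.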